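The source may report more compounds than this note shows. Statements on the series, on what has been measured and on what is new or still open speak of the compounds shown alone.

Measured compounds:
compound 1, `Nc1ccc(OCCCCCn2ccc(=O)[nH]c2=O)cc1`
compound 2, `Cc1cc(C)cc(OCCCCCn2ccc(=O)[nH]c2=O)c1`
compound 3, `O=c1ccn(CCCCCCOc2ccc(Br)cc2)c(=O)[nH]1`

In an ADME assay on HEL cells (Homo sapiens) for cytotoxicity, read by microscopy (a lower number here means that less compound is tolerated, a higher number that more compound is tolerated), compound 1 gives > 100000 nM, which is a limit of the assay rather than a number. Compound 2 likewise gives only a limit, > 100000 nM. Compound 3 gives a number, 20000 nM. So compound 1 stands at the upper end of what the assay reports, together with compound 2, while compound 3 alone sits at a measured concentration; the limit of > 100000 nM in this assay, at which 2 of the 3 values shown sit, is where two of the three values rest, and no pair of these compounds differs in a single place.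

Compound 4, `O=c1ccn(CCCCCOc2ccccc2)c(=O)[nH]1`, is not yet measured in this assay. It differs from compound 1 by hydrogen in place of amino on an aromatic carbon. Since compound 1 and compound 2 both reach the limit, and compound 3 with its bromine gives a number, the removal of the amino group is expected to make little difference beyond the scatter; the step of a number no higher from compound 1 to compound 4 (the limit leaves the size open) is estimated as none of consequence, with the result likely again a limit. For compound 4 the expected value is 100000 nM, with a range from 30000 nM to 300000 nM.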

Compound 4, minimum cytotoxic concentration: > 100000 nM
Compound 4 was reported as a limit; the forecaster's own chance of this, stated with the estimate: 60%; the middle value sits exactly at the limit.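

In this assay compound 4 gives > 100000 nM, a limit and not a number. Going by these compounds alone, compound 1 likewise gives a limit, > 100000 nM, so no step from one to the other can be read. The compounds shown leave open whether hydrogen in place of amino on an aromatic carbon changes the result in this assay at all.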